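Methylpiperazinyl for diethylamino on the amide chain

A few compounds are considered here, and "the series" means these few. Any claim that something is new, unique, unknown or untested is made for them only; others in the source may bear on it.

Compound 1 `COc1ccc(-c2cc3ccc(OC)cc3nc2Nc2ccc(NC(=O)CN3CCCCC3)cc2)cc1` and compound 2 `COc1ccc(-c2cc3ccc(OC)cc3nc2Nc2ccc(NC(=O)CN3CCN(C)CC3)cc2)cc1` differ only in the amine on a saturated chain carbon bound to a carbonyl carbon. In a functional assay on MCF7 cells (Homo sapiens) for antiproliferative activity, read by MTT assay, with a stated time of 48 h (on this read-out lower numbers stand for stronger inhibition and higher numbers for weaker inhibition), compound 1 gives 47900 nM. In this assay compound 2 gives 2800 nM. The step is large: a 17-fold lower number from compound 1 to compound 2 (1.23 log units; beyond the scatter). Compound 3 `CCN(CC)CC(=O)Nc1ccc(Nc2nc3ccc(OC)cc3cc2-c2ccc(OC)cc2)cc1` carries a diethylamino group at the same place. In this assay compound 3 gives only a limit of the assay, > 50000 nM, and sits at the limit of > 50000 nM in this assay, at which 1 of the 3 values shown sits; it is therefore the weakest point of the series on the numbers shown, without a number of its own.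

Compound 4 `COc1ccc(-c2cc3cc(OC)ccc3nc2Nc2ccc(NC(=O)CN3CCN(C)CC3)cc2)cc1` is not yet measured. Its change from compound 3 is 4-methylpiperazin-1-yl in place of diethylamino on a saturated chain carbon bound to a carbonyl carbon. Going by the values given here, the only measured step that bears on it is the exchange of a cyclic tertiary amine for 4-methylpiperazin-1-yl, a 17-fold lower number from compound 1 to compound 2 (1.23 log units; beyond the scatter), which moved the number strongly downward. A similar downward step is expected from compound 3 to compound 4, an at least 10-fold lower number from compound 3 to compound 4 (1.00 log units; beyond the scatter), although with a limit as the starting point its size is uncertain. Compound 4 is expected to give 5000 nM, within a range of 1500 nM to 40000 nM.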

Compound 4, half-maximal inhibitory concentration: 1800 nM
Beside the measured number, compound 4's estimate is 2.8-fold (0.44 log units) above it, and the stated range covers the measured number.
By their numbers in this assay, from the lowest: compounds 4 and 2 (each within the scatter of the next); then compound 1. At a limit, above all of these: compound 3.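

In this assay, the change gives an at least 27-fold lower number from compound 3 to compound 4 (1.44 log units; beyond the scatter), so the gain from 4-methylpiperazin-1-yl on a saturated chain carbon bound to a carbonyl carbon is not tied to a single leaving amine: it appears against open-chain diethylamino as well as against ring-bearing piperidin-1-yl. Compounds 2 and 4 differ only in where the methoxy group sits on the shared core and lie within the scatter of each other, so the 4-methylpiperazin-1-yl result holds with either arrangement. The true size of the step stays bounded, not fixed, since compound 3 gives a limit and not a number: the limit of > 50000 nM in this assay, at which 1 of the 4 values shown sits.

Open, from the compounds shown here alone, is which part of 4-methylpiperazin-1-yl carries the change. Piperazin-1-yl without the methyl, morpholin-4-yl with an oxygen for the second ring nitrogen, or a longer chain before the amine would separate these.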